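The source may report more compounds than this note shows. Statements on the series, on what has been measured and on what is new or still open speak of the compounds shown alone.

Measured compounds in a functional assay on PC-3 cells (Homo sapiens) for inhibition; a lower number here means a stronger inhibitor, a higher number a weaker inhibitor:
- Compound 1 `COc1cc2nc(N3CCN(S(=O)(=O)c4ccc([N+](=O)[O-])cc4)CC3)nc(N)c2cc1OC`: 36000 nM
- Compound 2 `COc1cc2nc(N3CCN(S(=O)(=O)c4ccc(C(C)(C)C)cc4)CC3)nc(N)c2cc1OC`: 4100 nM
- Compound 3 `COc1cc2nc(N3CCN(S(=O)(=O)c4cccc(C(=O)O)c4)CC3)nc(N)c2cc1OC`: 53000 nM

Compound 3 gives the highest number of the three in this assay; its nearest neighbour is compound 1, separated by a step within the scatter (a 1.5-fold higher number from compound 1 to compound 3 (0.17 log units; within the scatter)), while compound 2 stands furthest away (a 13-fold higher number from compound 2 to compound 3 (1.11 log units; beyond the scatter)).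

Compound 4 `COc1cc2nc(N3CCN(S(=O)(=O)c4ccc(C(=O)O)cc4)CC3)nc(N)c2cc1OC` has not yet been measured. It differs from compound 3 by a rearrangement of the same atoms: 4-carboxyphenyl in place of 3-carboxyphenyl on a sulfonyl sulfur.

Going by the values given here, no measured step isolates this change. Both compound 1 and compound 2 carry their substituent as a 4-substituted phenyl, and compound 3 as a 3-carboxyphenyl, so the steps of a 1.5-fold higher number from compound 1 to compound 3 (0.17 log units; within the scatter) and a 13-fold higher number from compound 2 to compound 3 (1.11 log units; beyond the scatter) each mix the change of group with the change of its place. Among the compounds with values here, the one relevant comparison, a 1.5-fold higher number from compound 1 to compound 3 (0.17 log units; within the scatter), stays within the scatter, which offers no basis for expecting a move beyond the scatter in either direction.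

Compound 4 is therefore expected to sit close to compound 3, at about 40000 nM (range 13000 nM to 120000 nM), a step of a 1.3-fold lower number from compound 3 to compound 4 (0.12 log units; within the scatter).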

Compound 4, half-maximal inhibitory concentration: 53000 nM
Beside the measured number, compound 4's estimate is 1.3-fold (0.12 log units) below it; low and high end bracket the measured number.
By their numbers in this assay, from the lowest: compound 2; then compounds 1, 3 and 4 (each within the scatter of the next).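

In this assay, the carboxy group's place on the phenyl ring can now be read on its own, and exchanging 3-carboxyphenyl for 4-carboxyphenyl on the sulfonyl sulfur leaves the number unmoved: no change at the digits printed from compound 3 to compound 4 (within the scatter). The group can also be compared at a fixed place on the aromatic carbon, where carboxy in place of tert-butyl gives a 13-fold higher number from compound 2 to compound 4 (1.11 log units; beyond the scatter), while carboxy in place of nitro gives a 1.5-fold higher number from compound 1 to compound 4 (0.17 log units; within the scatter), so carboxy and nitro are not separated and only tert-butyl stands apart. Nothing available accounts for either outcome.

Going by these compounds, whether a methyl ester of the carboxylic acid or an amine on the same ring would follow carboxy and nitro or tert-butyl remains open. Also open, on these data alone, is whether a longer alkyl chain would give a lower number than compound 2 does.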